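Bromo on the phenol ring of compound 1

The compounds below may be only part of what the source reports. "The series", "measured", "known", "first", "only" and "open" are said of these compounds alone.

In a physicochemical assay for solubility, measured as kinetic solubility (on this read-out lower numbers stand for lower solubility and higher numbers for higher solubility), compound 1 `CCC/N=C1\S/C(=C\c2ccc(O)cc2)C(=O)N1c1ccccc1C` gives 79000 nM and holds the higher of the two numbers on hand. Compound 3 `CCC/N=C1\S/C(=C\c2ccc(O)c(Cl)c2)C(=O)N1C(C)C` gives 20000 nM as the nearest number, lower than compound 1 by more than the scatter. Compound 2 `Cc1ccccc1N1C(=O)/C(=C/c2ccc(O)c(Cl)c2)S/C1=N\CCO` reads > 250000 nM and this is a limit of the assay, not a number.

Compound 4 `CCC/N=C1\S/C(=C\c2ccc(O)c(Br)c2)C(=O)N1c1ccccc1C` has bromo in place of hydrogen on an aromatic carbon of compound 1, ortho to a hydroxy group and meta to a large group bromo in place of hydrogen on an aromatic carbon and the same difference reads 4-hydroxyphenyl to 3-bromo-4-hydroxyphenyl. Among the measured compounds shown here, no pair of measured compounds shows this change on its own, so the expectation rests on indirect evidence. Compound 3 keeps the propyl chain, carries chloro on the same ring and gives 20000 nM in this assay as the basis for expecting a lower number. Compound 2 also carries chloro and goes against that reading, so the range is kept wide. A fall beyond the scatter is expected, with a 3.2-fold lower number from compound 1 to compound 4 (0.50 log units; beyond the scatter) as the estimated size of the step in this assay for now. For compound 4 the expected value is 25000 nM with an estimated range from 8000 nM to 70000 nM in this assay as the working figure.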

Compound 4, solubility: 79000 nM
Compound 4: the middle estimate sits 3.2-fold (0.50 log units) below what was measured; measured number above the stated range.
By their numbers in this assay, from the lowest: compound 3; then compounds 1 and 4 (each within the scatter of the next). At a limit, above all of these: compound 2.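

In this assay, bromo in place of hydrogen on an aromatic carbon, ortho to a hydroxy group, gives no change at the digits printed from compound 1 to compound 4 (within the scatter) on the core of compound 1. Among the compounds shown here, this is the first step that isolates a single change, and it shows that, with everything else held as in compound 1, this position takes bromo with no shift in the read-out beyond the scatter. The earlier compounds could not show this, as compounds 2 and 3 each differ from compound 1 in more than one place, and nothing measured here gives a reason for the flat step.

Still open, going by these compounds, is whether this carbon stays as flat for other groups, such as chloro, a methoxy group, an amine or a carboxylic acid, which would carry a different kind of atom into the same place. Also open, on these data alone, is whether the bromo step holds at the same size when the propyl chain gives way to a longer chain or a hydroxyethyl chain, or when the group on the ring nitrogen changes to isopropyl.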